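This account rests on a few compounds, and the source may have more. Where it says the series, first, only, none or still open, it means among the compounds named here.

Among the compounds with values here, in a functional assay on A549 cells (Homo sapiens) for antiproliferative activity, read by MTT assay, with a stated time of 72 h (on this read-out lower numbers stand for stronger inhibition and higher numbers for weaker inhibition), compound 2, with structure `COc1cc2c(Nc3ccc(C#N)cc3)ncnc2cc1OCCCN1CCCCC1`, gives 23500 nM, the only number among the three measured compounds. Compound 1, with structure `COc1cc2c(Nc3ccc(C#N)cc3)ncnc2cc1OCCCN(C)Cc1ccccc1`, reaches only the limit of > 100000 nM in this assay. Compound 3, with structure `COc1cc2c(Nc3ccc(C#N)cc3)ncnc2cc1OCCCN1CCC(CO)CC1`, likewise reaches only the limit of > 100000 nM. Within the data shown here, two of the three results therefore sit at the limit of > 100000 nM in this assay, at which 2 of the 3 values shown sit, so that compound 2 stands alone as the one compound with a readable value. Compound 4, with structure `CCOC(=O)C1CCN(CCCOc2cc3ncnc(Nc4ccc(C#N)cc4)c3cc2OC)CC1`, carries ethoxycarbonyl in place of hydrogen on a saturated ring carbon. The measured step that bears most directly on this change is an at least 4.2-fold higher number from compound 2 to compound 3 (0.62 log units; beyond the scatter), in which a group enters at the same saturated ring carbon. The step of an at least 4.2-fold lower number from compound 1 to compound 2 (0.62 log units; beyond the scatter) shows that the unsubstituted ring itself is the one arrangement with a readable number. An ethoxycarbonyl at the same ring position is therefore expected to move compound 4 the same way, toward a higher number, and compound 4 is estimated at 100000 nM (range 35000 nM to 300000 nM), which would mean a step of a 4.3-fold higher number from compound 2 to compound 4 (0.63 log units; beyond the scatter), most likely ending in a limit rather than a number.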

Compound 4, half-maximal inhibitory concentration: 89900 nM
For compound 4 the middle estimate is 1.1-fold (0.05 log units) above the measured one; measured number inside the range.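

At the saturated ring carbon three ring bonds from the ring nitrogen, ethoxycarbonyl in place of hydrogen gives, in this assay, a 3.8-fold higher number from compound 2 to compound 4 (0.58 log units; beyond the scatter), the first readable size for a group entering at this carbon, where hydroxymethyl had left only a limit. Against the other two compounds only floors can be stated, an at least 1.1-fold lower number from compound 3 to compound 4 (0.04 log units; that floor lies within the scatter) and an at least 1.1-fold lower number from compound 1 to compound 4 (0.04 log units; that floor lies within the scatter), and neither floor separates compound 4 from them beyond the scatter. Compound 1 and compound 3 remain limits of the assay and not numbers: the limit of > 100000 nM in this assay, at which 2 of the 4 values shown sit.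

The compounds shown leave open whether any other group at this ring carbon, such as a carboxylic acid, an amine or a methyl, would match or improve on compound 2. They also leave open how a longer chain to the piperidin-1-yl ring would read.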